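The source may hold more compounds than are shown below. What is called first, only, known or untested is meant among the compounds shown, and "the series" means these compounds.

Working notes on the series, all read in an ADME assay on L6 cells (Rattus norvegicus) for cytotoxicity; on this read-out lower numbers stand for stronger inhibition and higher numbers for weaker inhibition. The core of compound 1 `Cn1[nH]c(=O)c2cc([N+](=O)[O-])ccc21` is shared by every compound here. Compound 1 gives > 517000 nM, and this value is a limit, not a number. Compound 2 `O=c1c2cc([N+](=O)[O-])ccc2[nH]n1Cc1ccccc1` gives 234000 nM. Compound 3 `O=c1c2cc([N+](=O)[O-])ccc2[nH]n1Cc1ccccn1` gives 287000 nM. For the measured compounds named here, compound 2 and compound 3 hold the only two numeric values in this assay, and they cannot be separated: replacing phenyl with pyridin-2-yl on a saturated chain carbon bound to an aromatic nitrogen gives a 1.2-fold higher number from compound 2 to compound 3 (0.09 log units; within the scatter).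

Compound 4 `Cn1c2ccc([N+](=O)[O-])cc2c(=O)n1Cc1ccccc1` changes compound 2 elsewhere: methyl in place of hydrogen on an aromatic nitrogen. Going by the values given here, the one measured step, a 1.2-fold higher number from compound 2 to compound 3 (0.09 log units; within the scatter), bears on this only indirectly, since it concerns the benzyl group and leaves that nitrogen untouched. Among the compounds with values here, no measured pair shows this methyl change directly, so the expectation rests on that single small step and carries a wide range. No shift beyond the scatter is expected, and the estimated step is a 1.2-fold lower number from compound 2 to compound 4 (0.07 log units; within the scatter). For compound 4 the expected value is 200000 nM, with an estimated range of 80000 nM to 450000 nM.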

Compound 4, half-maximal inhibitory concentration: 43400 nM
Compound 4: middle estimate off by 4.6-fold (0.66 log units), on the high side; measured number outside the range, below it.
By their numbers in this assay, from the lowest: compound 4; then compounds 2 and 3 (each within the scatter of the next). At a limit, above all of these: compound 1.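

In this assay, for the compounds shown here, the aromatic nitrogen next to the ring atom that bears a benzyl group is the first place where a single change moves the number beyond the scatter: methyl in place of hydrogen gives a 5.4-fold lower number from compound 2 to compound 4 (0.73 log units; beyond the scatter), whereas the earlier change on the benzyl group, a 1.2-fold higher number from compound 2 to compound 3 (0.09 log units; within the scatter), did not separate its pair. With a methyl on an aromatic nitrogen in both compounds, benzyl in place of hydrogen on the other aromatic nitrogen gives an at least 11-fold lower number from compound 1 to compound 4 (1.07 log units; beyond the scatter), so the benzyl group and the methyl together carry the lowest number in the series. That second step is open on one side, as compound 1 stands at a limit and not at a number: the limit of > 517000 nM in this assay, at which 1 of the 4 values shown sits.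

The compounds shown leave open whether the lower number belongs to methyl alone or would also go with a longer chain, such as ethyl or propyl, or with a chain ending in an amine or a carboxylic acid on that aromatic nitrogen. Also open, on these data alone, is whether the methyl step holds with pyridin-2-yl in place of phenyl, as a single pair carries it so far.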